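Compound 2 and its 2-hydroxyphenyl counterpart, compound 4

This account rests on a few compounds, and the source may have more. Where it says the series, first, only, none or still open, it means among the compounds named here.

Measured so far in a functional assay on SK-BR-3 cells (Homo sapiens) for inhibition, read by MTT assay; a higher number here means a weaker inhibitor of growth, a lower number a stronger inhibitor of growth:
Compound 1 `CC1=C(/C=C/C(C)=C/C=C/C(C)=C\C(=O)NCc2cccc(F)c2)C(C)(C)CCC1n1ccnc1` gives 4240 nM
Compound 2 `CC1=C(/C=C/C(C)=C/C=C/C(C)=C\C(=O)Nc2ccc(F)cc2)C(C)(C)CCC1n1ccnc1` gives 25100 nM
Compound 3 `CC1=C(/C=C/C(C)=C/C=C/C(C)=C\C(=O)Nc2ccccc2)C(C)(C)CC=C1c1cncnc1` gives 31000 nM

Among these three numbers, compound 2 stands at the weak end of the series. Its value lies within the scatter of that of compound 3, and only compound 1 is clearly stronger in this assay. The next compound, compound 4 `CC1=C(/C=C/C(C)=C/C=C/C(C)=C\C(=O)Nc2ccccc2O)C(C)(C)CCC1n1ccnc1`, keeps the core of compound 2 and changes one group, with 2-hydroxyphenyl in place of 4-fluorophenyl on an amide-type nitrogen.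

Among the measured compounds shown here, only one measured step bears on this change. It sits at the same amide-type nitrogen, where 4-fluorophenyl replaces 3-fluorobenzyl, and it is modest but beyond the scatter (a 5.9-fold higher number from compound 1 to compound 2 (0.77 log units; beyond the scatter)). That step shows that a change at this nitrogen can move the number by a modest amount, but it involves a different pair of groups. For the measured compounds named here, no measured compound carries a 2-hydroxyphenyl group, so the direction is uncertain. With compound 2 already at 25100 nM, a modest move towards a lower number is expected. The estimated step is a 2.1-fold lower number from compound 2 to compound 4 (0.32 log units; beyond the scatter) (expected, not measured). For compound 4 the estimated value is 12000 nM (expected range 3500 nM to 40000 nM).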

Compound 4, concentration for 50% growth inhibition: 3890 nM
For compound 4 the middle estimate is 3.1-fold (0.49 log units) above the measured one; the measured number falls inside the stated range.
By their numbers in this assay, from the lowest: compounds 4 and 1 (each within the scatter of the next); then compounds 2 and 3 (each within the scatter of the next).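

Changing the group on the amide-type nitrogen of this core can also take the number down in this assay, with a 6.5-fold lower number from compound 2 to compound 4 (0.81 log units; beyond the scatter), so the weak value of compound 2 is not shared by every phenyl-type group at this position. The earlier step could be read as a loss on going from a benzyl to a phenyl-type group, but a 1.1-fold lower number from compound 1 to compound 4 (0.04 log units; within the scatter) places the 2-hydroxyphenyl group of compound 4 level with the 3-fluorobenzyl group of compound 1, which rules out that simple reading for these compounds. No measured evidence here explains the size of either step.

This change removes the fluorine and brings in the hydroxyl at a different named place on the ring, so the compounds shown do not separate the effect of the group from the effect of its place. As far as these compounds go, that question stays open, and 4-hydroxyphenyl, 2-fluorophenyl, 2-methoxyphenyl or 2-aminophenyl on the same nitrogen of this core would help to separate the two.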